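The source may hold more compounds than are shown below. What is called first, only, known or untested is meant among the compounds shown, and "the series" means these compounds.

The study concerns agonism at the receptor followed in a functional assay on CHO cells for agonist activity at Alpha-1A adrenergic receptor (Homo sapiens), read by FLIPR and calcium flux; on this read-out higher numbers stand for larger maximal responses and lower numbers for smaller maximal responses. Of the compounds shown here, three carry numbers so far. Compound 1, `COc1c(C)ccc2c1CCC2c1ncc[nH]1`, reaches 40% in this assay. Compound 2, `Cn1nccc1-c1cccc2c1CCC2c1ncc[nH]1`, reaches 58%, the higher of the two single numbers, and its margin over compound 1 lies beyond the usual scatter. Compound 3, `CS(=O)(=O)Nc1cccc2c1CCCC2c1ncc[nH]1`, has several entries and gives 47%; 79%; 79% (3 entries); the spread seen in the several entries of compound 3 in this assay, 47%; 79%; 79% (3 entries) shows how far repeated runs of one compound can drift. Going by the values given here, no two measured compounds differ in only one place, so no measured step is available.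

Compound 4, `c1cc(-c2ncco2)c2c(c1)C(c1ncc[nH]1)CC2`, is not yet measured. It departs from compound 2 in one place: 1,3-oxazol-2-yl in place of 1-methyl-1H-pyrazol-5-yl on an aromatic carbon. Each group is one five-membered aromatic ring with 2 hetero atoms, and the one that enters is the smaller. Without a measured step to lean on, the expected change for a number 8 percentage points lower from compound 2 to compound 4 (within the scatter) is a modest drop or none beyond the scatter. Compound 4 is expected to reach 50%, within a range from 30% to 75%.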

Compound 4, largest response reached (Emax), in percent of the reference or control that the assay uses: 63%
Estimate against measurement, compound 4: 13 percentage points below, and the stated range covers the measured number.
By their numbers in this assay, from the lowest: compound 1; then compounds 2 and 4 (each within the scatter of the next).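

Going by these compounds alone, the exchange of 1-methyl-1H-pyrazol-5-yl for 1,3-oxazol-2-yl on this aromatic carbon provides the first measured step in the set: in this assay it gives a number 5 percentage points higher from compound 2 to compound 4 (within the scatter). At this place, then, one five-membered aromatic ring with 2 hetero atoms can stand in for another, smaller one without a change in maximal response that can be told from the scatter. A single step of this size carries limited weight, and repeated runs of one compound can drift much further: the several entries of compound 3 in this assay, 47%; 79%; 79% (3 entries)

The compounds shown leave open how a group of another kind, such as an amine or a carboxylic acid, would fare at this place. They also leave open whether the same exchange would give a similar result on the core of compound 3.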